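The compounds below may be only part of what the source reports. "The series", "measured", "known", "first", "only" and "open" are said of these compounds alone.

In a functional assay on DU-145 cells (Homo sapiens), read by sulforhodamine B assay, with a stated time of 5 days (on this read-out lower numbers stand for stronger inhibition of growth and higher numbers for weaker inhibition of growth), compound 3 `OC[C@H]1O[C@@H](n2cc(Cl)c3c(-c4ccco4)ncnc32)[C@H](O)[C@@H]1O` gives > 10000 nM, which is a limit of the assay and not a number. It therefore stands at the limit of > 10000 nM in this assay, at which 1 of the 3 values shown sits, and no exact position in the series can be given for it.

Compound 4 `OC[C@H]1O[C@@H](n2cc(Cl)c3c(-c4cccs4)ncnc32)[C@H](O)[C@@H]1O` differs from compound 3 by thiophen-2-yl in place of furan-2-yl on an aromatic carbon.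

Going by the values given here, no measured step covers this exchange directly, so the evidence is indirect. Compound 2 `OC[C@H]1O[C@@H](n2cc(Cl)c3c(-c4ccccc4)ncnc32)[C@H](O)[C@@H]1O`, with phenyl on the same carbon, gives 140 nM. Among the compounds with values here, the one measured step in a single place is an at least 71-fold higher number from compound 2 to compound 3 (1.85 log units; beyond the scatter), with furan-2-yl in place of phenyl. The group at this carbon can thus move the read-out by a large amount, and the furan-2-yl compound is the outlier of the pair.

Compound 1 `OC[C@H]1O[C@@H](n2cc(F)c3c(-c4cccs4)ncnc32)[C@H](O)[C@@H]1O` already carries thiophen-2-yl, with fluoro rather than chloro on the shared core, and gives 9 nM. This value suggests that thiophen-2-yl is compatible with strong growth inhibition, although the halogen exchange itself has not been measured on its own.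

A large step towards a lower number is therefore expected, and the estimated change is an at least 330-fold lower number from compound 3 to compound 4 (2.52 log units; beyond the scatter). Compound 4 is expected at about 30 nM, with an estimated range of 6 nM to 200 nM.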

Compound 4, concentration for 50% growth inhibition: 13 nM
The estimate for compound 4 lay 2.3-fold (0.36 log units) above the measured number; measured number inside the range.
By their numbers in this assay, from the lowest: compounds 1 and 4 (each within the scatter of the next); then compound 2. At a limit, above all of these: compound 3.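

In this assay, the exchange of two five-membered aromatic rings, each with one hetero atom, gives an at least 760-fold lower number from compound 3 to compound 4 (2.88 log units; beyond the scatter), so at this carbon sulfur in the ring in place of oxygen separates a compound with strong growth inhibition from one without a measurable value. Compound 3 remains a limit of the assay and not a number: the limit of > 10000 nM in this assay, at which 1 of the 4 values shown sits. On the same chloro core, thiophen-2-yl also goes clearly beyond phenyl, with an 11-fold lower number from compound 2 to compound 4 (1.03 log units; beyond the scatter), while chloro in place of fluoro with thiophen-2-yl held constant gives a 1.4-fold higher number from compound 1 to compound 4 (0.16 log units; within the scatter), so this halogen exchange does not separate the two compounds and the group on the aromatic carbon accounts for the large steps among the compounds shown.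

From the compounds shown here alone, it remains open whether the sharp difference between the two five-membered rings extends to thiophen-3-yl, furan-3-yl or thiazol-2-yl, or to a non-aromatic substituent such as an amine on this carbon. Going by these compounds, it is also open whether furan-2-yl behaves the same with fluoro on the core, or whether hydrogen or methyl can replace the halogen alongside thiophen-2-yl.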